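This account rests on a few compounds, and the source may have more. Where it says the series, first, only, none or still open, it means among the compounds named here.

In a functional assay on Vero cells (Chlorocebus sabaeus) for inhibition (on this read-out higher numbers stand for weaker inhibition and lower numbers for stronger inhibition), compound 3 (`Clc1nc(-c2ccco2)c2ncn(Cc3ccc(Cl)c(Cl)c3)c2n1`) stands only at a limit, > 10 ug/mL. Compound 1 (`Clc1ccc(Cn2cnc3c(-c4ccco4)ncnc32)cc1Cl`) also gives only a limit, > 10 ug/mL. Together they mark (the limit of > 10 ug/mL in this assay, at which 2 of the 3 values shown sit). Compound 2 (`CCOc1ccc(Cn2cnc3c(-c4ccco4)ncnc32)cc1`) gives an actual number, 37.4 ug/mL. Compound 4 (`Fc1ccc(Cn2cnc3c(-c4ccco4)nc(Cl)nc32)cc1`) differs from compound 3 in one place: 4-fluorophenyl in place of 3,4-dichlorophenyl on a saturated chain carbon bound to an aromatic nitrogen. Within the data shown here, the only measured step, a step that the two limits leave unreadable from compound 1 to compound 3, concerns the chloro that compound 4 keeps, not this exchange, and its size cannot be read. Among the measured compounds shown here, no step of known size or direction is therefore expected in this assay, and the expected value stays near the limit of compound 3. The estimated step is a step that the limit leaves unreadable from compound 3 to compound 4. For compound 4 the expected value is 15 ug/mL, within an estimated range of 5 ug/mL to 50 ug/mL.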

Compound 4, half-maximal inhibitory concentration: 11.5 ug/mL
Compound 4: middle estimate off by 1.3-fold (0.12 log units), on the high side; measured number inside the range.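

In this assay no step can be read from compound 3 to compound 4, because compound 3 gives only a limit: the limit of > 10 ug/mL in this assay, at which 2 of the 4 values shown sit. The compounds shown leave open both the size and the direction of the effect of 4-fluorophenyl in place of 3,4-dichlorophenyl.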